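Chloro to methyl on compound 2

The source may hold more compounds than are shown below. What is called first, only, known or untested is meant among the compounds shown, and "the series" means these compounds.

Measured so far (values from a functional assay on RS4-11 cells (Homo sapiens) for inhibition, read by CCK-8 assay, with a stated time of 48 h; a lower number here means a stronger inhibitor, a higher number a weaker inhibitor)
- compound 1 `COc1ccc(S(=O)(=O)Oc2ccccc2/C=C(\C#N)C(=O)Nc2nnc(Cc3cccc4ccccc34)s2)cc1` gives 1360 nM
- compound 2 `COc1ccc(S(=O)(=O)Oc2ccccc2/C=C(\C#N)C(=O)Nc2nnc(Cc3ccc(Cl)cc3)s2)cc1` gives 1250 nM

Within the data shown here, compound 2, at 1250 nM on these numbers, stands level with compound 1, and the one measured step lies within the scatter (a 1.1-fold lower number from compound 1 to compound 2 (0.04 log units; within the scatter)). Compound 3 `COc1ccc(S(=O)(=O)Oc2ccccc2/C=C(\C#N)C(=O)Nc2nnc(Cc3ccc(C)cc3)s2)cc1` differs from compound 2 in one place, with methyl in place of chloro on an aromatic carbon, para to a large group (methyl in place of chloro on an aromatic carbon). Among the measured compounds shown here, no measured step makes this exchange directly. For the measured compounds named here, the only evidence nearby is the exchange of naphthalen-1-yl for 4-chlorophenyl on the saturated chain carbon, and compound 2 stayed within the scatter of compound 1 through that whole-group change (a 1.1-fold lower number from compound 1 to compound 2 (0.04 log units; within the scatter)). One step is thin support, but on this basis the exchange of chloro for methyl is expected to give no step beyond the scatter in this assay for either direction. The expected step is small (estimated as a 1.0-fold higher number from compound 2 to compound 3 (0.02 log units; within the scatter)). Compound 3 is expected at 1300 nM (estimated range 650 nM to 2600 nM).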

Compound 3, half-maximal inhibitory concentration: 1010 nM
Compound 3: the middle estimate sits 1.3-fold (0.11 log units) above what was measured; measured number inside the range.
By their numbers in this assay, from the lowest: compounds 3, 2 and 1 (each within the scatter of the next).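

Among these compounds, the change on the aromatic carbon para to a large group can now be read directly for the first time: with one heavy atom replacing another, chloro to methyl, this assay gives a 1.2-fold lower number from compound 2 to compound 3 (0.09 log units; within the scatter). The second new comparison extends the earlier result for the group on the saturated chain carbon, giving a 1.3-fold lower number from compound 1 to compound 3 (0.13 log units; within the scatter), so naphthalen-1-yl, 4-chlorophenyl and 4-methylphenyl are all within the scatter of one another in this assay, and neither the para substituent nor the wider group exchange separates these compounds. No supporting measurement is available to explain this flat response.

The compounds shown leave open whether this flatness holds for groups of a different kind, since an amine, a carboxylic acid or a longer chain such as butyl at the same aromatic carbon might give a step beyond the scatter. They also leave open whether the shared core itself governs the number, as all three compounds carry it unchanged and only the group on the saturated chain carbon varies.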